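The source may report more compounds than this note shows. Statements on the series, on what has been measured and on what is new or still open speak of the compounds shown alone.

Compound 1 `OC(CCn1nc2c(Br)c(Br)c(Br)c(Br)c2n1)c1cccc(Cl)c1`: 110%
Compound 2 `C[C@@H](O)CCn1nc2c(Br)c(Br)c(Br)c(Br)c2n1`: 88%
Compound 3 `OC(CCn1nc2c(Br)c(Br)c(Br)c(Br)c2n1)c1ccc(Cl)cc1`: 105%

In a functional assay on CCRF-CEM cells (Homo sapiens) for antiproliferative activity, read by MTT assay, with a stated time of 24 h, tested at 12.5 uM (a lower number here means a stronger effect, a higher number a weaker effect of the compound at the concentration tested), compound 2 gives the lowest of the three numbers; compound 3 stands above it and compound 1 further above, both gaps beyond the scatter. Compound 4 `OCC(O)Cn1nc2c(Br)c(Br)c(Br)c(Br)c2n1` has not been measured; it differs from compound 2 by 1,2-dihydroxyethyl in place of 2-hydroxypropyl on a saturated chain carbon bound to an aromatic nitrogen. Among the measured compounds shown here, the only measured step between compounds that differ in one place is a number 5 percentage points lower from compound 1 to compound 3 (within the scatter), which concerns the aryl group at the far end of the chain and does not bear on a change at the saturated chain carbon bound to the aromatic nitrogen. For the measured compounds named here, no measured step informs this change. Compound 4 is therefore expected to remain near compound 2. The expected step is a number 7 percentage points higher from compound 2 to compound 4 (within the scatter), none beyond the scatter. Compound 4 is estimated at 95%, within 78% to 112%.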

Compound 4, a percentage reported as activity, at one concentration (the size of the read-out at that concentration, not a potency): 78%
Beside the measured number, compound 4's estimate is 17 percentage points above it; low and high end bracket the measured number.
By their numbers in this assay, from the lowest: compounds 4 and 2 (each within the scatter of the next); then compounds 3 and 1 (each within the scatter of the next).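

At the saturated chain carbon bound to an aromatic nitrogen, this assay now gives a first measured step, a number 10 percentage points lower from compound 2 to compound 4 (within the scatter) and so 1,2-dihydroxyethyl in place of 2-hydroxypropyl, with 2 hydrogen-bond donors instead of 1 and no defined stereocentre, does not separate these two compounds. Nothing measured here accounts for this result. Going by these compounds, whether an amine, a carboxylic acid or a longer chain at this place would give a step beyond the scatter remains open.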